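Chain length on the base and cell growth inhibition

This account rests on a few compounds, and the source may have more. Where it says the series, first, only, none or still open, it means among the compounds named here.

Measured compounds:
compound 1 `CCCc1cn([C@H]2C[C@@H]3OP(=O)(O)OC[C@H]3O2)c(=O)[nH]c1=O`, compound 2 `CCCCCc1cn([C@H]2C[C@@H]3OP(=O)(O)OC[C@H]3O2)c(=O)[nH]c1=O`.

In a functional assay on L1210 cells (Mus musculus) (a higher number here means a weaker inhibitor, a lower number a stronger inhibitor), compound 1 gives only a limit, > 500 ug/mL. In this assay compound 2 likewise gives only a limit, > 500 ug/mL. Compound 2 thus stands at the limit of > 500 ug/mL in this assay, at which 2 of the 2 values shown sit. Both values being limits, the step that the two limits leave unreadable from compound 1 to compound 2 is not readable in size. Compound 3 `CCCCc1cn([C@H]2C[C@@H]3OP(=O)(O)OC[C@H]3O2)c(=O)[nH]c1=O` is not yet measured in this assay; it differs from compound 2 by hydrogen in place of methyl on a saturated chain carbon, four bonds along the chain from an aromatic carbon. Going by the values given here, only the step that the two limits leave unreadable from compound 1 to compound 2 bears on this change, and it gives no readable size. Compound 3 is expected to stay at the same limit. For compound 3 the estimate in this assay is 500 ug/mL, with a range from 300 ug/mL to 2000 ug/mL. The expected step is a number no higher from compound 2 to compound 3 (the limit leaves the size open), none beyond the scatter.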

Compound 3, concentration for 50% inhibition: 33.5 ug/mL
For compound 3 the middle estimate is 15-fold (1.17 log units) above the measured one; the whole stated range lies above it.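

In this assay, the chain on the base now has a readable effect, with an at least 14-fold lower number from compound 2 to compound 3 (1.17 log units; beyond the scatter) and an at least 14-fold lower number from compound 1 to compound 3 (1.17 log units; beyond the scatter). Among the compounds shown, the butyl chain of compound 3 therefore gives a measurable value, whereas the chains one carbon shorter and one carbon longer do not: the limit of > 500 ug/mL in this assay, at which 2 of the 3 values shown sit.

From the compounds shown here alone, the step between the two limits cannot be read, so how far compound 1 and compound 2 lie beyond that limit stays open. Also open, going by these compounds, is whether a hexyl chain, or a butyl chain ending in an amine or a carboxylic acid, would keep this inhibition.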